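Moving the Alkoxy Group on the Pendant Phenyl Ring

The compounds below may be only part of what the source reports. "The series", "measured", "known", "first", "only" and "open" are said of these compounds alone.

Compound 1 `CCOc1cccc(-c2ccc([C@H]3S[C@@H](C)C(=O)Nc4c3c(C)nn4-c3ccccc3C)cc2)c1` shows the lowest number of the three measured compounds in an assay on isolated protein for agonist activity at Bile acid receptor (Homo sapiens), read by AlphaScreen, with a stated time of 30 min; on this read-out higher numbers stand for larger maximal responses and lower numbers for smaller maximal responses; in this assay compound 1 gives 13%. Compound 3 `Cc1cccc(-n2nc(C)c3c2NC(=O)[C@H](C)S[C@@H]3c2ccc(Oc3ccccc3)cc2)c1` gives 22%, which lies within the scatter of compound 1, while compound 2 `CCCc1ccccc1-n1nc(C)c2c1NC(=O)[C@H](C)S[C@@H]2c1ccc(Oc2ccccc2)cc1` gives 240%, far beyond it. Compound 4 `COc1ccccc1-c1ccc([C@H]2S[C@@H](C)C(=O)Nc3c2c(C)nn3-c2ccccc2C)cc1` differs from compound 1 by 2-methoxyphenyl in place of 3-ethoxyphenyl on an aromatic carbon. Within the data shown here, the only measured step, a number 218 percentage points lower from compound 2 to compound 3 (beyond the scatter), concerns the group on the aromatic nitrogen, a different place, so no measured step bears directly on this change. Without such guidance the estimated step is a number 2 percentage points higher from compound 1 to compound 4 (within the scatter), with nothing expected beyond the scatter. Compound 4 is therefore expected to give about 15% in this assay, within a range of 4% to 45%.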

Compound 4, largest response reached (reported as efficacy), in percent of the reference or control that the assay uses: 50%
Compound 4: the middle estimate sits 35 percentage points below what was measured; the whole stated range lies below it.
By their numbers in this assay, from the lowest: compounds 1 and 3 (each within the scatter of the next); then compound 4; then compound 2.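

Replacing 3-ethoxyphenyl with 2-methoxyphenyl on the aromatic carbon gives a number 37 percentage points higher from compound 1 to compound 4 (beyond the scatter) in this assay. This shows that the group at this position can change the maximal response, whereas the earlier step showed this only for the group on the aromatic nitrogen. No available evidence accounts for the rise.

Going by these compounds, the change alters both where the alkoxy group sits and the length of its chain, so the contribution of each stays open. On these data alone, how an amine or a carboxylic acid in place of the methoxy group would behave also remains unknown.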